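This account rests on a few compounds, and the source may have more. Where it says the series, first, only, none or still open, it means among the compounds named here.

Measured compounds:
- compound 1, `COc1cccc(C2C(C#N)=C(N)Oc3cc(OC)ccc32)c1`, 52000000 nM
- compound 2, `CCNc1ccc2c(c1)OC(N)=C(C#N)C2c1cc(OC)c(OC)c(OC)c1`, 49000000 nM
- compound 3, `CCNc1ccc2c(c1)OC(N)=C(C#N)C2c1cccc(OC)c1`, 110000000 nM

In a functional assay on T47D cells (Homo sapiens) for activation (on this read-out lower numbers stand for an effect already at smaller amounts and higher numbers for an effect only at larger amounts of compound), compound 3 stands with the highest number of the three; compound 1 sits nearest to it, and compound 2 furthest. Among the measured compounds shown here, the one step that changes a single place, a 2.1-fold higher number from compound 1 to compound 3 (0.33 log units; beyond the scatter), swaps the group on the ring of the shared core and so says nothing directly about the methoxy count on the pendant ring. Compound 4, `CCNc1ccc2c(c1)OC(N)=C(C#N)C2c1cc(OC)cc(OC)c1`, differs from compound 3 by methoxy in place of hydrogen on an aromatic carbon; the newcomer is meta to a methoxy group already present. For the measured compounds named here, no step isolates this change. Compound 2, which carries three methoxy groups on that ring, gives a lower number in this assay than compound 3, and compound 4 sits between the two in substitution. Compound 4 is therefore expected to give a somewhat lower number, a step of a 1.6-fold lower number from compound 3 to compound 4 (0.20 log units; within the scatter), and its estimated value is 70000000 nM, within 35000000 nM to 140000000 nM.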

Compound 4, half-maximal effective concentration: 61700000 nM
Compound 4: middle estimate off by 1.1-fold (0.05 log units), on the high side; the range from low to high includes it.
By their numbers in this assay, from the lowest: compounds 2, 1, 4 and 3 (each within the scatter of the next, the first and the last beyond it).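

In this assay the methoxy in place of hydrogen on an aromatic carbon, meta to a methoxy group, can now be read on its own, and it gives a 1.8-fold lower number from compound 3 to compound 4 (0.25 log units; within the scatter) and so stays within the scatter. The step that takes away a methoxy group from the pendant ring of compound 2, a 1.3-fold higher number from compound 2 to compound 4 (0.10 log units; within the scatter), also stays within the scatter, so neither single change on this ring separates the compounds in question, unlike the change on the shared core seen earlier. Nothing available bears on why these numbers stand as they do.

On these data alone, whether a fluorine, an amine or a carboxylic acid at this carbon would give a step beyond the scatter stays open. So does the effect of a longer chain there, such as ethoxy.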